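A second fluorine on the urea ring, measured in rice

The source may report more compounds than this note shows. Statements on the series, on what has been measured and on what is new or still open speak of the compounds shown alone.

Compound 1 `CCc1cccc(NC(=O)N[C@@H](C)c2ccccc2)c1`: 100%
Compound 2 `C[C@H](NC(=O)Nc1cccc(F)c1)c1ccccc1`: 97%
Compound 3 `C[C@H](NC(=O)Nc1cccc(Br)c1)c1ccccc1`: 100%

In an ADME assay on the whole organism with Oryza sativa as the target, tested at 0.1 uM (a higher number here means a weaker effect of the compound at the concentration tested, a lower number a stronger effect), compound 1 gives 100%, compound 2 gives 97% and compound 3 gives 100%. Compound 2 sits together with the other two: a number 3 percentage points lower from compound 1 to compound 2 (within the scatter) and a number 3 percentage points higher from compound 2 to compound 3 (within the scatter) both stay within the scatter, as does no change at the digits printed from compound 1 to compound 3 (within the scatter), so swapping the single group on this ring has shown no effect so far.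

Compound 4 `C[C@H](NC(=O)Nc1ccc(F)c(F)c1)c1ccccc1` differs from compound 2 by fluoro in place of hydrogen on an aromatic carbon. Among the measured compounds shown here, no measured step adds a second group to this ring, so the three small steps are only an indirect guide; they suggest a change no larger than the scatter is expected, a number 1 percentage points higher from compound 2 to compound 4 (within the scatter). Compound 4 is therefore estimated at 98%, within 88% to 100%.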

Compound 4, a percentage reported as activity, at one concentration (the size of the read-out at that concentration, not a potency): 99%
Beside the measured number, compound 4's estimate is 1 percentage points below it, and the stated range covers the measured number.
By their numbers in this assay, from the lowest: compounds 2, 4, 1 and 3 (each within the scatter of the next).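

Until now, the compounds only exchanged one group on this ring for another, whereas compound 4 carries a second group: a fluoro ortho to a fluoro group and para to a large group. In this assay this addition gives a number 2 percentage points higher from compound 2 to compound 4 (within the scatter), so at this place a fluoro does not separate the two compounds. Nothing available explains this result.

Going by these compounds, it remains open whether a different group at this place, such as an amine, a carboxylic acid or a longer chain, would give a step beyond the scatter.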